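Side-chain swaps on the shared core, compounds 1 to 4

This account rests on a few compounds, and the source may have more. Where it says the series, first, only, none or still open, it means among the compounds named here.

Measured in a functional assay for inhibition, with Homo sapiens as the target; a lower number here means a stronger inhibitor, a higher number a weaker inhibitor:
- compound 1 `CC(C)(C)Sc1c(CC(C)(C)C(=O)O)n(Cc2ccc(Cl)cc2)c2ccc(CCc3ccc4ccccc4n3)cc12`: 4 nM
- compound 2 `CC(C)(C)Sc1c(CC(C)(C)C(=O)O)n(Cc2ccc(Cl)cc2)c2ccc(OCc3cccnc3)cc12`: 8 nM
- compound 3 `C[C@H](COc1ccc2c(c1)c(SC(C)(C)C)c(CC(C)(C)C(=O)O)n2Cc1ccc(Cl)cc1)c1ccccn1`: 3 nM

Compound 3 shares the low end of the series with compound 1, as shown by a 1.3-fold lower number from compound 1 to compound 3 (0.12 log units; within the scatter). Compound 4 `CC(C)c1csc(COc2ccc3c(c2)c(SC(C)(C)C)c(CC(C)(C)C(=O)O)n3Cc2ccc(Cl)cc2)n1` is the next to be read, with 4-isopropyl-1,3-thiazol-2-yl in place of 1-(pyridin-2-yl)ethyl on a saturated chain carbon bound to an oxygen on an aromatic ring.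

Within the data shown here, the only measured step at this same place is a 2.7-fold lower number from compound 2 to compound 3 (0.43 log units; beyond the scatter), and it is modest. The wider replacement on the aromatic carbon, a 1.3-fold lower number from compound 1 to compound 3 (0.12 log units; within the scatter), stays within the scatter. Among the measured compounds shown here, no measured compound carries a five-membered aromatic ring, so the direction is poorly defined. A small rise, not beyond the scatter, is expected, and the estimated step is a 1.7-fold higher number from compound 3 to compound 4 (0.22 log units; within the scatter). For compound 4 the estimated value is 5 nM, with an expected range of 2 nM to 15 nM.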

Compound 4, half-maximal inhibitory concentration: 3 nM
Estimate against measurement, compound 4: 1.7-fold (0.22 log units) above; low and high end bracket the measured number.
By their numbers in this assay, from the lowest: compounds 3, 4, 1 and 2 (each within the scatter of the next, the first and the last beyond it).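

In this assay a five-membered aromatic ring is accepted at this place, with no change at the digits printed from compound 3 to compound 4 (within the scatter) on going to 4-isopropyl-1,3-thiazol-2-yl, and compound 4 carries no defined stereocentre there. The same group gives a 2.7-fold lower number from compound 2 to compound 4 (0.43 log units; beyond the scatter) and also a 1.3-fold lower number from compound 1 to compound 4 (0.12 log units; within the scatter) so it sits with the 1-(pyridin-2-yl)ethyl and 2-(quinolin-2-yl)ethyl compounds rather than with the pyridin-3-yl compound. No measured evidence on the origin of these steps is available. Whether the isopropyl group matters remains open, since the plain 1,3-thiazol-2-yl group is absent from the compounds shown. From the compounds shown here alone, how a primary amine or a carboxylic acid on this chain would read is equally open.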